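Notes on the step from compound 2 to compound 3

A few compounds are considered here, and "the series" means these few. Any claim that something is new, unique, unknown or untested is made for them only; others in the source may bear on it.

Compound 1 `C[C@@H](/N=c1\c(O)c(O)\c1=N/c1ccc(C#N)cc1)C(C)(C)C` pairs a nitrile-bearing aryl ring with a branched alkyl on the other side of the shared core. In a functional assay for inhibition, with Rattus norvegicus as the target (a lower number here means a stronger inhibitor, a higher number a weaker inhibitor), compound 1 gives 370 nM; 24300 nM (2 entries); the two entries lie far apart, as shown by the several entries of compound 1 in this assay, 370 nM; 24300 nM (2 entries), so its position is uncertain. Compound 2 `Cc1cc(C#N)ccc1/N=c1\c(O)c(O)\c1=N/[C@H](C)C(C)(C)C` adds a methyl to the aryl ring. In this assay, among the measured compounds shown here, compound 2 gives 1080 nM, the only single number reported for it; one further entry for compound 2 carries no single number. Side by side, the value of compound 2 sits between the two entries of compound 1, and no measured step between the two compounds is available.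

Compound 3 `CCCc1cc(C#N)ccc1/N=c1\c(O)c(O)\c1=N/[C@H](C)C(C)(C)C` is not yet measured. It differs from compound 2 by ethyl in place of hydrogen on a saturated chain carbon bound to an aromatic carbon. With no measured step of this kind in the series, the step from compound 2 to compound 3 is expected to be small, at most a slight weakening, and is estimated as a 1.4-fold higher number from compound 2 to compound 3 (0.14 log units; within the scatter). In this assay compound 3 is expected to give 1500 nM, within 400 nM to 6000 nM.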

Compound 3, half-maximal inhibitory concentration: 23100 nM
Compound 3: middle estimate off by 15-fold (1.19 log units), on the low side, and the stated range ends below it.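

In this assay, among the compounds shown here, the change from methyl to propyl on the aryl ring gives a 21-fold higher number from compound 2 to compound 3 (1.33 log units; beyond the scatter), the first measured step and one beyond the scatter. The saturated chain carbon bound to an aromatic carbon is therefore not a neutral place for extension: adding ethyl there, with no ring, no hydrogen-bond donor or acceptor and no net charge, is enough to produce a large weakening. This reading rests on one entry for compound 3 and one single number for compound 2, and some caution is needed because entries for a single compound in this assay can lie far apart: the several entries of compound 1 in this assay, 370 nM; 24300 nM (2 entries)

The two points at this place do not show how the weakening builds up with chain length, so an ethyl group on the aryl ring, which would fall between methyl and propyl, would help define its course. Going by these compounds, it also remains open whether a longer chain such as butyl would weaken the compound further, and whether an amine or a carboxylic acid carried on the same chain would behave like propyl.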